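A Third Hydroxy Group Placed on Compound 1

The compounds below may be only part of what the source reports. "The series", "measured", "known", "first", "only" and "open" are said of these compounds alone.

Compound 1 `O=C(CCc1nc2ccccc2c(=O)[nH]1)N/N=C/c1ccc(O)c(O)c1` stands second highest of three numbers in a physicochemical assay, read by spectrophotometry, with a stated time of 15 min (on this read-out higher numbers stand for weaker inhibition and lower numbers for stronger inhibition), where compound 1 gives 105000000 nM. Compound 3 `O=C(CCCc1nc2ccccc2c(=O)[nH]1)N/N=C/c1cc(O)c(O)c(O)c1` gives 45000000 nM in this assay, and compound 2 `COc1ccc(/C=N/NC(=O)CCCc2nc3ccccc3c(=O)[nH]2)cc1` gives 280000000 nM. Among the compounds with values here, the only single-point step available, a 6.2-fold lower number from compound 2 to compound 3 (0.79 log units; beyond the scatter), reaches the 3,4,5-trihydroxyphenyl through a different change. Compound 4 `O=C(CCc1nc2ccccc2c(=O)[nH]1)N/N=C/c1cc(O)c(O)c(O)c1` differs from compound 1 by hydroxy in place of hydrogen on an aromatic carbon. Within the data shown here, no measured step isolates this exact change; compound 3 carries the 3,4,5-trihydroxyphenyl but differs from compound 1 elsewhere as well, so its value can only hint. The expectation in this assay is therefore a modest step downward, a 2.1-fold lower number from compound 1 to compound 4 (0.32 log units; beyond the scatter), and compound 4 is estimated at 50000000 nM, within 20000000 nM to 125000000 nM.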

Compound 4, half-maximal inhibitory concentration: 45000000 nM
Compound 4: the middle estimate sits 1.1-fold (0.05 log units) above what was measured; the measured number falls inside the stated range.
By their numbers in this assay, from the lowest: compounds 3 and 4 (each within the scatter of the next); then compound 1; then compound 2.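

Placed on the aromatic carbon ortho to a hydroxy group, the new hydroxy turns the 3,4-dihydroxyphenyl into the 3,4,5-trihydroxyphenyl and gives a 2.3-fold lower number from compound 1 to compound 4 (0.37 log units; beyond the scatter) in this assay, the first reading of this change on its own. Compound 3, which carries the same 3,4,5-trihydroxyphenyl on a different chain, prints the same number as compound 4. Nothing available explains the step. Going by these compounds, it remains open whether an amine or a carboxylic acid on this aromatic carbon would give a similar number. On these data alone, whether a longer chain would alter the step also remains open.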